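The compounds below may be only part of what the source reports. "The series", "measured", "known", "first", "only" and "open" are said of these compounds alone.

Compound 1 `CC(C)CCn1c(=O)c(C2=NS(=O)(=O)c3cc(NS(C)(=O)=O)ccc3N2)c(O)n2nc(C3CC3)cc12`: > 100000 nM
Compound 2 `CC(C)CC[C@@]1(C)C(=O)C(C2=NS(=O)(=O)c3cc(NS(C)(=O)=O)ccc3N2)=C(O)c2cccn21`: 19500 nM

Both entries come from an ADME assay on Huh-7 cells (Homo sapiens) for cytotoxicity; on this read-out higher numbers stand for lower toxicity in this test and lower numbers for higher toxicity in this test. For compound 1, > 100000 nM is a limit of the assay and not a number. Within the data shown here, compound 2, at 19500 nM, therefore holds the only actual number so far.

Compound 3 `CC(C)CCC1(C)C(=O)C(C2=NS(=O)(=O)c3cc(NS(C)(=O)=O)ccc3N2)=C(O)c2cccn21` has not yet been measured. The structural change is the two compounds have the same atoms and bonds; at least one stereo element is drawn with a configuration in one of them and without one in the other: 1 of 1 stereo elements differ; a stereocentre at a saturated ring carbon is drawn S in compound 2 and without a configuration in compound 3. Among the measured compounds shown here, no measured pair shows what such a change does, so the expectation rests on compound 2 at 19500 nM. With the same atoms and bonds in both compounds, no shift beyond the usual scatter is expected in this assay, in either direction. The expected change is a 1.1-fold higher number from compound 2 to compound 3 (0.05 log units; within the scatter). For compound 3 the estimated value is 22000 nM, with an expected range of 10000 nM to 48000 nM.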

Compound 3, half-maximal cytotoxic concentration: > 100000 nM
Compound 3 was reported as a limit; the forecaster's own chance of this, stated with the estimate: 15%; at least 4.5-fold (0.65 log units) between middle value and limit.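

In this assay, a change that leaves every atom and bond in place still comes with a step beyond the usual scatter: an at least 5.1-fold higher number from compound 2 to compound 3 (0.70 log units; beyond the scatter). The only difference is that the stereocentre at a saturated ring carbon is drawn S in compound 2 and without a configuration in compound 3. Compound 3 gives > 100000 nM, which is a limit of the assay and not a number, so the step gives only a minimum size, because the top of the measurable range sets where it stops: the limit of > 100000 nM in this assay, at which 2 of the 3 values shown sit.

The compounds shown leave open how a form with the opposite configuration at this stereocentre would behave, and whether compound 3 contains one. Also open, going by these compounds, is what an amine or a carboxylic acid on this saturated ring carbon would do in this assay.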